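The compounds below may be only part of what the source reports. "The series", "measured", "known", "first", "only" and "open" are said of these compounds alone.

Measured so far in a functional assay, with a stated time of 20 min, tested at 10 uM; on this read-out higher numbers stand for a stronger effect at the one concentration tested and lower numbers for a weaker effect:
compound 1 `COc1cc(/C=C/C(=O)C2=C(/C=C/c3ccc(O)c(OC)c3)NC(=O)NC2c2ccccc2O)ccc1O`: 71%
compound 2 `COc1cc(/C=C/C(=O)C2=C(/C=C/c3ccc(O)c(OC)c3)NC(=O)NC2c2ccc(N(C)C)cc2)ccc1O`: 69.9%
compound 3 `COc1cc(/C=C/C(=O)C2=C(/C=C/c3ccc(O)c(OC)c3)NC(=S)NC2c2ccccc2O)ccc1O`: 70.8%

Compound 1 and compound 3 share most of their structure, but the difference between the two cores is not broken down here; their values in this assay lie within the scatter of each other. The change from compound 1 to compound 2 is 4-(dimethylamino)phenyl in place of 2-hydroxyphenyl on a saturated ring carbon, and it gave a number 1.1 percentage points lower from compound 1 to compound 2 (within the scatter).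

Compound 4 `COc1cc(/C=C/C(=O)C2=C(/C=C/c3ccc(O)c(OC)c3)NC(=S)NC2c2ccc(N(C)C)cc2)ccc1O` is not yet measured. It stands to compound 3 as compound 2 stands to compound 1: the change is 4-(dimethylamino)phenyl in place of 2-hydroxyphenyl on a saturated ring carbon, made at the same place. For compound 4 the expected step in this assay is a number 1.1 percentage points lower from compound 3 to compound 4 (within the scatter), which rests on a number 1.1 percentage points lower from compound 1 to compound 2 (within the scatter) and on compound 3 giving 70.8%. Compound 4 is therefore estimated at 69.7%, expected to fall between 60% and 79%.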

Compound 4, a percentage reported as activity, at one concentration (the size of the read-out at that concentration, not a potency): 59%
Compound 4: the middle estimate sits 10.7 percentage points above what was measured; the whole stated range lies above it.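

On the core of compound 3, 4-(dimethylamino)phenyl in place of 2-hydroxyphenyl gave a number 11.8 percentage points lower from compound 3 to compound 4 (beyond the scatter) in this assay. Set beside the same change on the core of compound 1, this step cannot be told apart from the earlier one: the same change on two cores in this assay, a number 1.1 percentage points lower (within the scatter) from compound 1 to compound 2 and a number 11.8 percentage points lower (beyond the scatter) from compound 3 to compound 4, 10.7 percentage points apart, within the scatter of two such steps. The data therefore give no firm sign that the effect of this change depends on the core, but with one pair per core they do not show that the step is the same on both, and they say nothing about any other core.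

Open, as far as these compounds go, is how other groups on the saturated ring carbon would behave on either core, such as a phenyl carrying a carboxylic acid or a primary amine. Also open, from the compounds shown here alone, is the effect of a simple alkyl chain in place of the 2-(4-hydroxy-3-methoxyphenyl)ethenyl group.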